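The compounds below may be only part of what the source reports. "The series", "measured", "known", "first", "only" and "open" are said of these compounds alone.

Measured so far:
Compound 1, `O=C(NCCCN1CCC(Cc2ccccc2)CC1)c1ccc(CO[N+](=O)[O-])cc1`, in an assay on membranes from brain for displacement of a labelled ligand from Sigma non-opioid intracellular receptor 1 (Cavia porcellus), read by scintillation counting, with a stated time of 1 h (a lower number here means a stronger inhibitor, a higher number a weaker inhibitor), gives 145 nM.
Compound 2, `O=C(NCCCCN1CCC(Cc2ccccc2)CC1)c1ccc(CO[N+](=O)[O-])cc1`, in this assay gives 250 nM.

Compound 2 has the higher of the two numbers, but its gap to compound 1 lies within the scatter, so the two are not told apart. The next compound, compound 3, `Cc1ccc(C(=O)NCCCCN2CCC(Cc3ccccc3)CC2)cc1`, differs from compound 2 by hydrogen in place of nitrooxy on a saturated chain carbon bound to an aromatic carbon. Within the data shown here, no comparable step has been measured, so the expectation rests on the change alone: a small step, likely toward a lower number or none beyond the scatter. Compound 3 is estimated at 150 nM, between 50 nM and 500 nM, a step of a 1.7-fold lower number from compound 2 to compound 3 (0.22 log units; within the scatter).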

Compound 3, inhibition constant: 62 nM
The estimate for compound 3 lay 2.4-fold (0.38 log units) above the measured number, within the range that was stated.
By their numbers in this assay, from the lowest: compound 3; then compounds 1 and 2 (each within the scatter of the next).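

Replacing nitrooxy with hydrogen on this saturated chain carbon bound to an aromatic carbon gives a step beyond the scatter in this assay, a 4.0-fold lower number from compound 2 to compound 3 (0.61 log units; beyond the scatter). This shows that the group on this carbon matters to the number, and that nitrooxy is not required for binding here, since the simple methyl of compound 3 gives the lower number. Nothing measured here explains the step. Going by these compounds, whether a hydroxyl, an amine or a carboxylic acid on this carbon would lower or raise the number remains open. So does whether the same change on the chain of compound 1 would give a step of similar size.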